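The source may report more compounds than this note shows. Statements on the series, on what has been measured and on what is new or still open speak of the compounds shown alone.

Measured in a functional assay on K562 cells (Homo sapiens) for cytotoxicity, read by MTT assay, with a stated time of 3 days (a higher number here means a weaker inhibitor, a lower number a stronger inhibitor), are:
compound 1 `N#Cc1c(Nc2ccccc2)nc(SCc2nc3ccccc3[nH]2)nc1-c1ccccc1` with 3.2 nM
compound 2 `CNc1nc(SCc2nc3ccccc3[nH]2)nc(-c2ccccc2)c1C#N` with 13.2 nM

Compound 2 holds the higher of the two numbers, at 13.2 nM in this assay here. Compound 3 `N#Cc1c(Nc2nccs2)nc(SCc2nc3ccccc3[nH]2)nc1-c1ccccc1` differs from it as follows: 1,3-thiazol-2-yl in place of methyl on a nitrogen on an aromatic ring in short, 1,3-thiazol-2-yl in place of methyl on a nitrogen on an aromatic ring. Going by the values given here, the one measured step that bears on this is a 4.1-fold higher number from compound 1 to compound 2 (0.62 log units; beyond the scatter) for methyl in place of phenyl on such a nitrogen, a modest step beyond the scatter. Compound 3 again carries an aromatic ring on that nitrogen, so a step of like size is expected in this assay toward a lower number. Among the compounds with values here, no compound with 1,3-thiazol-2-yl has been measured, so this expectation rests on compound 1 alone. The estimated step is a 2.9-fold lower number from compound 2 to compound 3 (0.47 log units; beyond the scatter) in all. For compound 3 the expected value is 4.5 nM with an estimated range of 1.3 nM to 15 nM around it.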

Compound 3, half-maximal inhibitory concentration: 14.7 nM
Compound 3: middle estimate off by 3.3-fold (0.51 log units), on the low side; low and high end bracket the measured number.
By their numbers in this assay, from the lowest: compound 1; then compounds 2 and 3 (each within the scatter of the next).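

In this assay, an aromatic ring on this nitrogen proved not to be enough to match the phenyl compound: 1,3-thiazol-2-yl in place of methyl gives a 1.1-fold higher number from compound 2 to compound 3 (0.05 log units; within the scatter). Phenyl thus stands apart from 1,3-thiazol-2-yl as well as from methyl, with the exchange for 1,3-thiazol-2-yl giving a 4.6-fold higher number from compound 1 to compound 3 (0.66 log units; beyond the scatter), much as the exchange for methyl gave a 4.1-fold higher number from compound 1 to compound 2 (0.62 log units; beyond the scatter). No available evidence accounts for this difference between the two aromatic rings.

The compounds shown leave open whether a pyridinyl ring or a methoxyphenyl group on this nitrogen would fall with compound 1 or with compound 2 and compound 3. They also leave open how a benzyl group or a longer chain such as n-butyl would compare in this assay.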